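Dithiocarbamate amine swap on a shared benzamide core

The source may report more compounds than this note shows. Statements on the series, on what has been measured and on what is new or still open speak of the compounds shown alone.

Measured compounds in a functional assay on A-375 cells (Homo sapiens) for antiproliferative activity, read by CCK-8 assay, with a stated time of 72 h, tested at 8 uM; a lower number here means a weaker effect, a higher number a stronger effect of the compound at the concentration tested: compound 1 `Nc1ccccc1NC(=O)c1ccc(CSC(=S)N2CCCc3ccccc32)cc1` gives 81.5%; compound 2 `Nc1ccccc1NC(=O)c1ccc(CSC(=S)N2CCN(c3ncccn3)CC2)cc1` gives 67.9%; compound 3 `Nc1ccccc1NC(=O)c1ccc(CSC(=S)N2CCN(c3ccncc3)CC2)cc1` gives 90.7%.

Compound 1 stands second highest of the three numbers. Its nearest neighbour is compound 3, which lies higher but within the scatter; the furthest is compound 2, which lies lower and beyond the scatter. Among the measured compounds shown here, the only measured step within this set, a number 22.8 percentage points higher from compound 2 to compound 3 (beyond the scatter), changes the aryl group on the amine nitrogen in a ring of the dithiocarbamate portion and is modest in size.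

Compound 4 `CN(Cc1cccnc1)C(=S)SCc1ccc(C(=O)Nc2ccccc2N)cc1` has not yet been measured. It differs from compound 1 in one place: methyl((pyridin-3-yl)methyl)amino in place of 1,2,3,4-tetrahydroquinolin-1-yl on a thiocarbonyl carbon. This change sits in the same dithiocarbamate region as the step from compound 2 to compound 3, but it swaps the whole amine rather than a substituent on it, so that step offers only a loose guide. The measured steps show that changes at this position can move this assay by a modest amount in either direction, with nothing pointing clearly one way.

Compound 4 is therefore expected to give 76% in this assay, with a range from 60% to 90%, a step of a number 5.5 percentage points lower from compound 1 to compound 4 (within the scatter) that is expected to stay within the scatter.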

Compound 4, a percentage reported as inhibition, at one concentration (the size of the read-out at that concentration, not a potency): 83.8%
For compound 4 the middle estimate is 7.8 percentage points below the measured one, and the stated range covers the measured number.
By their numbers in this assay, from the lowest: compound 2; then compounds 1, 4 and 3 (each within the scatter of the next).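

In this assay, the exchange of the whole amine on the thiocarbonyl carbon gives a number 2.3 percentage points higher from compound 1 to compound 4 (within the scatter), so methyl((pyridin-3-yl)methyl)amino and 1,2,3,4-tetrahydroquinolin-1-yl cannot be told apart in this read-out, even though the entering group has no non-aromatic ring and carries a hydrogen-bond acceptor that the leaving group lacks. The earlier step, a number 22.8 percentage points higher from compound 2 to compound 3 (beyond the scatter), concerned only the aryl group on an amine nitrogen in a ring, whereas this one shows that a full replacement of the amine can leave the read-out within the scatter. No measurement shown here explains why these two amines give readings within the scatter of each other.

The compounds shown leave open whether a plain dimethylamino group, with no aromatic ring, or a longer chain in place of the methyl on methyl((pyridin-3-yl)methyl)amino would keep the read-out at this level. Each number is also the size of the effect at a single concentration rather than a potency, so any difference in potency between compound 1 and compound 4 remains unresolved.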